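The compounds below may be only part of what the source reports. "The series", "measured", "known", "first", "only" and "open" are said of these compounds alone.

Three close relatives of one shared core have been measured in a functional assay on HepG2 cells (Homo sapiens) for inhibition, read by CCK-8 assay, with a stated time of 72 h, tested at 20 uM; on this read-out higher numbers stand for more inhibition of growth at the one concentration tested and lower numbers for less inhibition of growth. Compound 1 `CCCCc1ccc2c(c1)/C(=C\C(=O)OC(C)(C)C)C(=O)N2` gives 90.3%, compound 2 `COc1ccc2c(c1)/C(=C\C(=O)OC(C)(C)C)C(=O)N2` gives 90.1%, and compound 3 `COc1cccc2c1NC(=O)/C2=C/C(=O)OC(C)(C)C` gives 87.3%. Compound 2 stands second highest of these three numbers, yet its distance to compound 1 and its distance to compound 3 both lie within the usual scatter, so the three values cannot really be told apart.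

The next compound, compound 4 `CC(C)(C)OC(=O)/C=C1/C(=O)Nc2ccc([N+](=O)[O-])cc21`, has not yet been tested in this assay. It differs from compound 2 in one place: nitro in place of methoxy on an aromatic carbon. Within the data shown here, only one measured step changes a group at that position: a number 0.2 percentage points lower from compound 1 to compound 2 (within the scatter), a swap that left the number within the scatter. With every measured value sitting close to the others, no movement beyond the scatter is expected here either. The expected step is a number 2.1 percentage points lower from compound 2 to compound 4 (within the scatter). Compound 4 is therefore expected to give about 88%, with a likely range from 76% to 96%.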

Compound 4, percent growth inhibition at one concentration: 88.2%
Compound 4: middle estimate off by 0.2 percentage points, on the low side; the measured number falls inside the stated range.
By their numbers in this assay, from the lowest: compounds 3, 4, 2 and 1 (each within the scatter of the next).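

In this assay the swap from methoxy to nitro on this aromatic carbon gives a number 1.9 percentage points lower from compound 2 to compound 4 (within the scatter) and the swap from butyl to nitro gives a number 2.1 percentage points lower from compound 1 to compound 4 (within the scatter) and so neither step can be told apart from ordinary repeat-to-repeat variation. The earlier pair showed only that butyl and methoxy could not be told apart here, whereas nitro brings a different set of atoms, one nitrogen and two oxygens, and the result still cannot be distinguished from the other two at the one concentration tested. Nothing available here explains this result.

As far as these compounds go, what an amine or a carboxylic acid on this carbon would do remains open. So does the question of whether these compounds would separate at lower concentrations, which a single-concentration read-out cannot show.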